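Saturating the ring double bond: compound 2 to compound 3

The source may report more compounds than this note shows. Statements on the series, on what has been measured and on what is new or still open speak of the compounds shown alone.

Measured compounds:
- compound 1, `COc1ccc(CN(C)Cc2ccc(C3=CCCN(C)C3)cc2)cc1`: in a functional assay on HL-60 cells (Homo sapiens) for inhibition (on this read-out higher numbers stand for weaker inhibition and lower numbers for stronger inhibition), compound 1 gives "not determined" (no result reported)
- compound 2, `CN1CCC=C(c2ccc(CN(C)Cc3ccc(Cl)cc3)cc2)C1`: in this assay compound 2 gives 2140 nM

Within the data shown here, compound 2 carries the only number in the set; compound 1 has an entry without a value, so no comparison between the two can be made. Compound 3, `CN(Cc1ccc(Cl)cc1)Cc1ccc(C2CCCN(C)C2)cc1`, is not yet measured in this assay. Its difference from compound 2 is a group of 7 heavy atoms (6 carbon, 1 nitrogen; one six-membered non-aromatic ring with 1 hetero atom) in place of a group of 7 heavy atoms (6 carbon, 1 nitrogen; one six-membered non-aromatic ring with 1 hetero atom), on an aromatic carbon. The change is small in atom count and keeps the nitrogen and the six-membered non-aromatic ring; only the double bond outside aromatic rings is lost. Among the measured compounds shown here, no measured pair shows a step of this kind, so the expectation rests on the single value of compound 2 alone. The step is expected to be no larger than the usual scatter, with at most a slight shift toward weaker inhibition: a 1.4-fold higher number from compound 2 to compound 3 (0.15 log units; within the scatter). For compound 3 the expected value in this assay is 3000 nM, with a range from 1000 nM to 9000 nM.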

Compound 3, half-maximal inhibitory concentration: 1290 nM
The estimate for compound 3 lay 2.3-fold (0.37 log units) above the measured number; measured number inside the range.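

In this assay, exchanging the ring that carries the double bond for 1-methylpiperidin-3-yl, on an aromatic carbon para to a large group, gives a 1.7-fold lower number from compound 2 to compound 3 (0.22 log units; within the scatter). Among these compounds, at this position, the double bond outside aromatic rings is therefore not required for the read-out to stay in the same range, something the single value of compound 2 could not show. Nothing measured on these compounds bears on the origin of this result.

Still open, from the compounds shown here alone, is whether the same holds for a pyrrolidine or morpholine ring on this aromatic carbon, or for a piperidine without the methyl group on its nitrogen. Also open, going by these compounds, is how a nitrile in place of the chlorine would affect the read-out on the saturated compound 3.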